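Replacing 4-hydroxyphenyl with 2,4-dichlorophenyl: working notes

A few compounds are considered here, and "the series" means these few. Any claim that something is new, unique, unknown or untested is made for them only; others in the source may bear on it.

In a functional assay on HeLa cells (Homo sapiens) for inhibition, read by trypan blue exclusion, with a stated time of 72 h (a lower number here means a stronger inhibitor of growth, a higher number a weaker inhibitor of growth), compound 2 (`CC/C(=C(\c1ccc(NC(=O)C(C)C)cc1)c1ccc(OC)cc1)c1ccc(O)cc1`) gives 3700 nM and compound 1 (`CC/C(=C(/c1ccc(NC(=O)C(C)C)cc1)c1ccc(OC)cc1)c1ccc(Cl)cc1Cl`) gives 2200 nM, two values within the scatter of each other. Compound 3 (`CC/C(=C(\c1ccc(NC(=O)C(C)C)cc1)c1ccc(OC)cc1)c1ccc(Cl)cc1Cl`) has 2,4-dichlorophenyl in place of 4-hydroxyphenyl on a double-bonded chain carbon bound to a double-bonded chain carbon and a saturated chain carbon. Going by the values given here, no measured pair shows the size of this change, so the expectation rests only on these two close values. A small step of a 1.5-fold lower number from compound 2 to compound 3 (0.17 log units; within the scatter) is expected in this assay, toward a lower number and within the scatter. For compound 3 the estimated value is 2500 nM, with an expected range of 1000 nM to 6000 nM.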

Compound 3, concentration for 50% growth inhibition: 5500 nM
For compound 3 the middle estimate is 2.2-fold (0.34 log units) below the measured one; the range from low to high includes it.
By their numbers in this assay, from the lowest: compounds 1, 2 and 3 (each within the scatter of the next, the first and the last beyond it).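

In this assay, 2,4-dichlorophenyl in place of 4-hydroxyphenyl on a double-bonded chain carbon bound to a double-bonded chain carbon and a saturated chain carbon gives a 1.5-fold higher number from compound 2 to compound 3 (0.17 log units; within the scatter), so this change does not separate the two groups with the double bond drawn as in these compounds. The step beyond the scatter is instead a 2.5-fold higher number from compound 1 to compound 3 (0.40 log units; beyond the scatter), and the only difference behind it is the drawn configuration: the fact that compounds 1 and 3 differ only in the configuration as drawn.

Open, as far as these compounds go, is whether the double-bond configuration matters equally with 4-hydroxyphenyl at this position, and whether an aminophenyl group there would give a step beyond the scatter.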